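Chloro for Methoxy, Repeated on a Second Core

This account rests on a few compounds, and the source may have more. Where it says the series, first, only, none or still open, it means among the compounds named here.

Compound 1 `COc1ccccc1N1CCN(CCn2nc(N3CCN(C(=O)c4ccco4)CC3)ccc2=O)CC1` and compound 2 `O=C(c1ccco1)N1CCN(c2ccc(=O)n(CCN3CCN(c4ccccc4Cl)CC3)n2)CC1` share a core and differ in one place: chloro in place of methoxy on an aromatic carbon. In an assay on cell membranes for binding affinity to Adrenergic receptor alpha-1 (Rattus norvegicus), read by radioligand binding (a higher number here means a weaker inhibitor, a lower number a stronger inhibitor), compound 1 gives 94.5 nM, while compound 2 gives 34 nM, so the change brought a 2.8-fold lower number from compound 1 to compound 2 (0.44 log units; beyond the scatter). Compound 3 `COc1ccccc1N1CCN(CCCCn2nc(N3CCN(C(=O)c4ccco4)CC3)ccc2=O)CC1` is built on a different core; the difference between the two cores is not broken down here. In this assay compound 3 gives 180 nM. Compound 4 `O=C(c1ccco1)N1CCN(c2ccc(=O)n(CCCCN3CCN(c4ccccc4Cl)CC3)n2)CC1` is the unmeasured partner of compound 3, made by the same change, at the same kind of place: chloro in place of methoxy on an aromatic carbon. Because the earlier pair gave a 2.8-fold lower number from compound 1 to compound 2 (0.44 log units; beyond the scatter), a step of similar size is expected here, a 2.8-fold lower number from compound 3 to compound 4 (0.44 log units; beyond the scatter). Compound 4 is therefore estimated at 65 nM in this assay, most likely between 30 nM and 140 nM.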

Compound 4, inhibition constant: 7.9 nM
Compound 4: middle estimate off by 8.2-fold (0.92 log units), on the high side, outside the stated range (below it).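

The change pointed the same way on the second core, giving a 23-fold lower number from compound 3 to compound 4 (1.36 log units; beyond the scatter) in this assay. Its size did not carry over, however, and the two steps differ by more than the scatter allows: the same change on two cores in this assay, a 2.8-fold lower number (0.44 log units; beyond the scatter) from compound 1 to compound 2 and a 23-fold lower number (1.36 log units; beyond the scatter) from compound 3 to compound 4, 8.2-fold (0.91 log units) apart, beyond the scatter of two such steps. Two pairs therefore show that the direction held on these two cores, but they do not explain why the size differed, and they give no reliable size for the step on any other core.

As far as these compounds go, it remains open whether fluoro or trifluoromethyl in the same place would follow the smaller step, the larger one or neither. It is also unknown how the same change would behave on a core with a longer chain.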